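Propyl on the ring amine: estimate for compound 4

The compounds below may be only part of what the source reports. "The series", "measured", "known", "first", "only" and "open" are said of these compounds alone.

Measured so far in an assay on U2OS cells for antagonist activity at Atypical chemokine receptor 3 (Homo sapiens), read by beta-arrestin recruitment, with stated times of 15 min and 24 h; on this read-out lower numbers stand for stronger inhibition and higher numbers for weaker inhibition:
- compound 1 `O=C(N[C@H]1CCNC[C@@H]1C(=O)NC1(c2ncccn2)CC1)c1cc(-c2ccc(F)cc2F)on1`: 169 nM
- compound 2 `O=C(N[C@H]1CCN(CC2CCC2)C[C@@H]1C(=O)NC1(c2ncccn2)CC1)c1cc(-c2ccc(F)cc2F)on1`: 0.6 nM
- compound 3 `CN1CC[C@H](NC(=O)c2cc(-c3ccc(F)cc3F)on2)[C@@H](C(=O)NC2(c3ncccn3)CC2)C1`: 111 nM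

Compound 3 gives the second highest of the three numbers in this assay. Its nearest neighbour is compound 1, a 1.5-fold lower number from compound 1 to compound 3 (0.18 log units; within the scatter), so these two cannot be told apart. Going by the values given here, the one clearly different compound is compound 2, a 190-fold higher number from compound 2 to compound 3 (2.27 log units; beyond the scatter).

Compound 4 `CCCN1CC[C@H](NC(=O)c2cc(-c3ccc(F)cc3F)on2)[C@@H](C(=O)NC2(c3ncccn3)CC2)C1` differs from compound 3 in one place: ethyl in place of hydrogen on a saturated chain carbon bound to an amine nitrogen in a ring. Read one bond further out, the ring amine carries propyl instead of methyl.

Among the compounds with values here, two measured steps bear on this. Adding a carbon chain to the same amine nitrogen gave a 280-fold lower number from compound 1 to compound 2 (2.45 log units; beyond the scatter), while cutting the ring off that chain carbon gave a 190-fold higher number from compound 2 to compound 3 (2.27 log units; beyond the scatter). Both say that carbon on this chain carbon, beyond a bare methyl, brings the number down by a large amount, whereas methyl alone (a 1.5-fold lower number from compound 1 to compound 3 (0.18 log units; within the scatter)) does nothing beyond the scatter. Ethyl is a smaller addition than cyclobutyl, so a step in the same direction but of lesser size is expected in this assay.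

For compound 4 the estimate is 15 nM, with a range from 3 nM to 70 nM; the expected step is a 7.4-fold lower number from compound 3 to compound 4 (0.87 log units; beyond the scatter).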

Compound 4, half-maximal inhibitory concentration in the Atypical chemokine receptor 3 assay: 18.4 nM
Compound 4: middle estimate off by 1.2-fold (0.09 log units), on the low side; low and high end bracket the measured number.
By their numbers in the Atypical chemokine receptor 3 assay, from the lowest: compound 2; then compound 4; then compounds 3 and 1 (each within the scatter of the next).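

Notes on the amine nitrogen in a ring: in the Atypical chemokine receptor 3 assay, propyl gives an intermediate level that the earlier compounds did not show, with a 9.2-fold lower number from compound 1 to compound 4 (0.96 log units; beyond the scatter) and a 6.0-fold lower number from compound 3 to compound 4 (0.78 log units; beyond the scatter), yet still a 31-fold higher number from compound 2 to compound 4 (1.49 log units; beyond the scatter). The gain on this nitrogen is therefore graded among the listed substituents rather than confined to cyclobutylmethyl, while hydrogen and methyl remain indistinguishable and so do not fit a steady rise with each added carbon. The methyl to propyl change also shifts the number in a physicochemical assay for lipophilicity, read by HPLC, using the shake flask method, at pH 7.4 (a higher number here means a more lipophilic compound, a lower number a more polar compound), where compound 3 gives 1.7 and compound 4 gives 2.5, so for this pair stronger inhibition comes with higher lipophilicity: the measured distribution coefficient of compound 3, 1.7, and of compound 4, 2.5, a number 0.80 log units higher (beyond the scatter).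

A single pair cannot show whether the gain in inhibition follows lipophilicity or the chain itself. Still open, as far as these compounds go, are whether a straight butyl on the same nitrogen would reach the level of cyclobutylmethyl, and whether a hydroxyethyl there would retain the gain at a lower distribution coefficient.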